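A few compounds are considered here, and "the series" means these few. Any claim that something is new, unique, unknown or untested is made for them only; others in the source may bear on it.

Working notes on the series. Compound 1 `CC1CCN(c2nc(=O)c3cc([N+](=O)[O-])cc([N+](=O)[O-])c3s2)CC1` and compound 2 `CC(C)(C)OC(=O)N1CCN(c2nc(=O)c3cc([N+](=O)[O-])cc([N+](=O)[O-])c3s2)CC1` share the core of the set, and in an ADME assay on Vero cells (Chlorocebus sabaeus) for cytotoxicity, read by MTT assay, with a stated time of 72 h (a lower number here means a stronger inhibitor, a higher number a weaker inhibitor), compound 1 gives "not determined" (no result reported) while compound 2 likewise gives "not determined" (no result reported), so neither contributes a number. Compound 3 `O=c1nc(NC2CC2)sc2c([N+](=O)[O-])cc(C(F)(F)F)cc12` carries a cyclopropylamino group and a trifluoromethyl group on the same core. In this assay compound 3 reaches only a limit, > 100000 nM, and no single number is available for it. This is the limit of > 100000 nM in this assay, at which 1 of the 3 values shown sits. Within the data shown here, with two entries lacking any result and one entry sitting at a limit, compound 3 stands at the edge of what the measurement resolves, and no step between measured compounds can be drawn from these data.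

Compound 4 `O=C(O)C1CCN(c2nc(=O)c3cc(C(F)(F)F)cc([N+](=O)[O-])c3s2)CC1` differs from compound 3 by the change (4-carboxypiperidin-1-yl in place of cyclopropylamino on an aromatic carbon), that is, 4-carboxypiperidin-1-yl in place of cyclopropylamino on an aromatic carbon. Among the measured compounds shown here, with no measured step to lean on, the expectation for this assay rests on compound 3 alone, whose value > 100000 nM is a limit; compound 4 is therefore expected to sit at or beyond that same limit, and the step that the limit leaves unreadable from compound 3 to compound 4 is estimated to be none beyond the scatter. Compound 4 is expected to give about 150000 nM, within a range of 60000 nM to 400000 nM.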

Compound 4, half-maximal inhibitory concentration: > 100000 nM
Compound 4: only a limit was reported (the forecaster's own chance of this, stated with the estimate: 75%); the middle value does not contradict the limit.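

No step can be read between compound 3 and compound 4 in this assay, because each of the two compounds gives only a limit: the limit of > 100000 nM in this assay, at which 2 of the 4 values shown sit.

The compounds shown leave open how far either compound lies from that limit, and whether 4-carboxypiperidin-1-yl in place of cyclopropylamino changes the result in this assay at all.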